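Swapping a sulfonyl group for a furanylmethyl on the amine

The compounds below may be only part of what the source reports. "The series", "measured", "known", "first", "only" and "open" are said of these compounds alone.

Compound 1 `CN(C1CCN(CCCc2c[nH]c3ccc(-n4cnnc4)cc23)CC1)S(=O)(=O)c1ccccc1` was tested in an assay on CHO cells for displacement of a labelled ligand from 5-hydroxytryptamine receptor 1D (Homo sapiens) (a higher number here means a weaker inhibitor, a lower number a stronger inhibitor), where compound 1 gives 1.5 nM. Two close relatives share its core. Compound 2 `CC(=O)Nc1ccc([C@H](C)NCC2CCN(CCCc3c[nH]c4ccc(-n5cnnc5)cc34)CC2)cc1` gives 0.6 nM, and compound 3 `CC(=O)Nc1ccc([C@@H](C)NCC2CCN(CCCc3c[nH]c4ccc(-n5cnnc5)cc34)CC2)cc1` gives 1.5 nM. Among the compounds with values here, the one measured step, a 2.5-fold higher number from compound 2 to compound 3 (0.40 log units; beyond the scatter), rests on (the fact that compounds 2 and 3 differ only in the configuration as drawn). On these numbers compound 1 sits level with compound 3 at the digits shown, the two together the highest of the three, while compound 2 lies a modest step lower.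

Compound 4 `CN(Cc1ccco1)C1CCN(CCCc2c[nH]c3ccc(-n4cnnc4)cc23)CC1` is the next compound to be measured. It differs from compound 1 in one place: (furan-2-yl)methyl in place of phenylsulfonyl on an amine nitrogen. Within the data shown here, none of the measured steps touches this kind of change; the only step available concerns configuration at a saturated chain carbon and says nothing about replacing phenylsulfonyl with (furan-2-yl)methyl on an amine nitrogen. All three measured compounds lie close together, so the shared core appears to carry much of the activity. Compound 4 is therefore expected to remain potent, with a step of a 2.0-fold higher number from compound 1 to compound 4 (0.30 log units; within the scatter) judged most likely, toward a slightly higher number. The estimate for compound 4 is 3 nM, between 0.8 nM and 12 nM.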

Compound 4, half-maximal inhibitory concentration: 9.3 nM
Compound 4: middle estimate off by 3.1-fold (0.49 log units), on the low side; the range from low to high includes it.
By their numbers in this assay, from the lowest: compound 2; then compounds 1 and 3 (each within the scatter of the next); then compound 4.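

Replacing phenylsulfonyl with (furan-2-yl)methyl on this amine nitrogen gives a 6.2-fold higher number from compound 1 to compound 4 (0.79 log units; beyond the scatter) in this assay, so the group placed here does affect the result, something the earlier compounds could not show because none of their listed steps involved this position. Even so, compound 4 gives 9.3 nM, which shows that a number of this order can be kept on this core without the phenylsulfonyl group. The information available on these compounds concerns only the drawn configuration of compounds 2 and 3, so it offers no explanation for this new step.

This single change alters two things at once: the sulfonyl link is lost, and the six-membered aromatic ring of carbon only gives way to a five-membered aromatic ring with one hetero atom, so the compounds shown leave open which of these matters more. A benzyl group on the same nitrogen would keep the carbon link of compound 4 while restoring the ring of compound 1, and would help separate the two contributions.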